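Methoxy to hydroxy on the aryl ring of compound 3

This account rests on a few compounds, and the source may have more. Where it says the series, first, only, none or still open, it means among the compounds named here.

Three compounds sharing one core have been examined in a functional assay on CCRF-CEM cells (Homo sapiens) for cytotoxicity, read by sulforhodamine B assay, with a stated time of 48 h, tested at 1 uM; a lower number here means a stronger effect, a higher number a weaker effect of the compound at the concentration tested. Compound 1 `COc1cc(C)cc(-c2c(-c3ccnc(-c4ccc(C(C)=O)cc4)c3)cnn2CC#N)c1` gives 12% there, compound 2 `Cc1cc(O)cc(-c2nn(CC#N)cc2-c2ccnc(-c3ccc(Oc4ccccc4)cc3)c2)c1` gives 6%, and compound 3 `COc1cc(C)cc(-c2nn(CC#N)cc2-c2ccnc(-c3ccc(N(C)C)cc3)c2)c1` gives 16%. Compound 3 carries the largest of the three numbers, yet its gap to compound 1 and its gap to compound 2 both lie within the usual scatter, so the three cannot be ranked against one another on this evidence.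

Compound 4 `Cc1cc(O)cc(-c2nn(CC#N)cc2-c2ccnc(-c3ccc(N(C)C)cc3)c2)c1` is obtained from compound 3 by one change: hydrogen in place of methyl on an oxygen on an aromatic ring. Read one bond further out, the change turns methoxy into hydroxy and 3-methoxy-5-methylphenyl into 3-hydroxy-5-methylphenyl. Among the measured compounds shown here, no measured pair differing only in this way is available, so the size of the resulting step in this assay is unknown. Compound 2, which already bears the hydroxy group, gives a number within the scatter of compound 3, which argues against a large move. Compound 4 is therefore expected to show a number 4 percentage points lower from compound 3 to compound 4 (within the scatter), a step not beyond the scatter. The estimated value of compound 4 is 12%, between 2% and 25%.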

Compound 4, a percentage reported as activity, at one concentration (the size of the read-out at that concentration, not a potency): 13%
Compound 4: middle estimate off by 1 percentage points, on the low side; measured number inside the range.
By their numbers in this assay, from the lowest: compounds 2, 1, 4 and 3 (each within the scatter of the next).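

In this assay the change from methoxy to hydroxy now has a measured pair, and hydrogen in place of methyl on an oxygen on an aromatic ring gives a number 3 percentage points lower from compound 3 to compound 4 (within the scatter), so this position shows no effect of the change that can be told from scatter. With the hydroxy group held in place, dimethylamino in place of phenoxy on an aromatic carbon gives a number 7 percentage points higher from compound 2 to compound 4 (within the scatter), so this exchange cannot be separated from scatter either. No measured information is available here to explain either result.

Going by these compounds, whether an amine, a carboxylic acid or a longer alkoxy chain such as butoxy in place of the hydroxy group would give a number beyond the scatter remains open. The values also come from a single concentration, which leaves any difference in potency among these compounds unresolved.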